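This account rests on a few compounds, and the source may have more. Where it says the series, first, only, none or still open, it means among the compounds named here.

Measured compounds and their values:
compound 1 `COc1cc(-c2nc3cc([N+](=O)[O-])ccc3[nH]2)ccc1O`, in a functional assay on aorta (Rattus norvegicus, strain Wistar) for inhibition, with a stated time of 60 min (on this read-out lower numbers stand for smaller maximal responses and higher numbers for larger maximal responses), compound 1 gives 55.2%
compound 2 `COc1cc(-c2nc3cc(C(F)(F)F)ccc3[nH]2)ccc1O`, compound 2 gives 97.7%
compound 3 `CCOc1ccccc1-c1nc2cc(C(F)(F)F)ccc2[nH]1`, compound 3 gives 19.8%

Compound 1 and compound 2 share one core and differ at a single place: nitro in place of trifluoromethyl on an aromatic carbon. The step that goes with this change is a number 42.5 percentage points lower from compound 2 to compound 1 (beyond the scatter).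

Compound 3 carries a different core; how the core of compound 3 differs from the core of compound 2 is not broken down here. Of the three measured compounds, compound 3 stands lowest in this assay, and the gaps to compound 1 and to compound 2 are both beyond the scatter.

Compound 4 `CCOc1ccccc1-c1nc2cc([N+](=O)[O-])ccc2[nH]1` is not yet measured. It differs from compound 3 in the same way that compound 1 differs from compound 2: nitro in place of trifluoromethyl on an aromatic carbon. The place of the change is the same, word for word, in both pairs, so it is the same change made on another core.

For compound 4 the expected step is a number 9.8 percentage points lower from compound 3 to compound 4 (within the scatter), a step in the same direction as a number 42.5 percentage points lower from compound 2 to compound 1 (beyond the scatter) but smaller, expected because compound 3 already gives 19.8% and the read-out cannot fall below zero. Compound 4 is therefore estimated at 10%, with a range from 0% to 30%.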

Compound 4, largest response reached (Emax), in percent of the reference or control that the assay uses: 46.4%
Beside the measured number, compound 4's estimate is 36.4 percentage points below it; the measured number lies above the stated range.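

In this assay, nitro in place of trifluoromethyl on an aromatic carbon gives a number 26.6 percentage points higher from compound 3 to compound 4 (beyond the scatter), so on the core of compound 3 the change moves the read-out the opposite way to the step seen on the core of compound 2. The change therefore does not carry over from one core to the other, in direction or in size: the same change on two cores in this assay, a number 42.5 percentage points lower (beyond the scatter) from compound 2 to compound 1 and a number 26.6 percentage points higher (beyond the scatter) from compound 3 to compound 4, 69.1 percentage points apart, beyond the scatter of two such steps This rests on two pairs only: it shows that the outcome of the change depends on the core in this series, but not which difference between the two cores sets the direction, nor what the change would do on any third core.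

Open, on these data alone, is whether the two cores part ways only for nitro and trifluoromethyl, or also for other groups on the same aromatic carbon, such as a nitrile, a carboxylic acid or an amine. Also open, as far as these compounds go, is whether a core with a chain longer than the ethoxy group of compound 3 would follow compound 3 and compound 4 or compound 1 and compound 2 when the same change is made.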